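The source may hold more compounds than are shown below. What is called first, only, known or untested is meant among the compounds shown, and "the series" means these compounds.

Compound 3, `FC(F)(F)c1ccc(-c2ccc3c(NCCCNCc4ccco4)ccnc3c2)cc1`, sits at the top of the three numbers in a physicochemical assay for acid dissociation, giving 9.47. Compound 1, `COc1ccccc1Oc1ccc2c(NCCCNCc3ccco3)ccnc2c1`, gives 9.28, and compound 2, `c1ccc(Oc2ccc3c(NCCCNCc4ccco4)ccnc3c2)cc1`, gives 9.28; the steps of a number 0.19 log units higher from compound 1 to compound 3 (within the scatter) and a number 0.19 log units higher from compound 2 to compound 3 (within the scatter) both lie within the scatter, so the three compounds are not separated. Compound 4, `c1coc(CNCCCNc2ccnc3cc(CC4CCCCC4)ccc23)c1`, is not yet measured. It differs from compound 3 by cyclohexylmethyl in place of 4-(trifluoromethyl)phenyl on an aromatic carbon. The two steps that exchanged the group on this same aromatic carbon, a number 0.19 log units higher from compound 1 to compound 3 (within the scatter) and a number 0.19 log units higher from compound 2 to compound 3 (within the scatter), were each within the scatter, so no step beyond the scatter is expected here either, that is a number 0.07 log units lower from compound 3 to compound 4 (within the scatter). Compound 4 is therefore estimated at 9.4, expected to fall between 9.05 and 9.75.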

Compound 4, acid dissociation constant: 9.47
Estimate against measurement, compound 4: 0.07 log units below; low and high end bracket the measured number.
By their numbers in this assay, from the lowest: compounds 1, 2, 3 and 4 (each within the scatter of the next).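

Among these compounds, compound 4 is the first to carry a non-aromatic ring on this aromatic carbon, and in this assay the exchange for 4-(trifluoromethyl)phenyl leaves the number unmoved (no change at the digits printed from compound 3 to compound 4 (within the scatter)). The exchanges for the oxygen-linked groups also stay small (a number 0.19 log units higher from compound 2 to compound 4 (within the scatter); a number 0.19 log units higher from compound 1 to compound 4 (within the scatter)). Across these four groups, then, the number at this position does not depend on an aromatic ring in the group.

No measurement offers an explanation for this constancy. As far as these compounds go, whether an amine or a carboxylic acid on this carbon would move the number beyond the scatter remains open.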